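Extending the Urea Terminus on a Shared Core

The source may report more compounds than this note shows. Statements on the series, on what has been measured and on what is new or still open speak of the compounds shown alone.

Measured so far in a functional assay on A549 cells (Homo sapiens) for cytotoxicity, read by MTT assay, with a stated time of 72 h; a higher number here means a weaker inhibitor, a lower number a stronger inhibitor:
compound 1 `COc1ncc(-c2ccc3nc(NC(=O)N(C)C)nn3c2)cc1NS(=O)(=O)c1ccc(F)cc1`: 1190 nM
compound 2 `COc1ncc(-c2ccc3nc(NC(=O)NCCN4CCN(C)CC4)nn3c2)cc1NS(=O)(=O)c1ccc(F)cc1`: 1050 nM
compound 3 `COc1ncc(-c2ccc3nc(NC(=O)NCCN(C)C)nn3c2)cc1NS(=O)(=O)c1ccc(F)cc1`: 800 nM

Compound 1 gives the highest of the three numbers, but its neighbours sit close: a 1.1-fold lower number from compound 1 to compound 2 (0.05 log units; within the scatter) and a 1.5-fold lower number from compound 1 to compound 3 (0.17 log units; within the scatter), both within the scatter, so no order among the three can be claimed.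

Compound 4 `COc1ncc(-c2ccc3nc(NC(=O)NCC(=O)N4CCOCC4)nn3c2)cc1NS(=O)(=O)c1ccc(F)cc1` differs from compound 1 only at the urea terminus: (((morpholin-4-yl)carbonyl)methyl)amino in place of dimethylamino on a carbonyl carbon. The two measured steps that bear on this change both swap the same dimethylamino group for a longer chain ending in an amine, and neither moved the number beyond the scatter. For the measured compounds named here, the new group carries a carbonyl and a ring instead of an amine chain end, which no measured pair covers, so the expectation rests only on the two small steps already seen.

Compound 4 is therefore expected to give about 1000 nM, with a range from 450 nM to 2200 nM. The step from compound 1 to compound 4 is expected to be a 1.2-fold lower number from compound 1 to compound 4 (0.08 log units; within the scatter), an estimated step that would stay within the scatter.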

Compound 4, half-maximal inhibitory concentration: 2570 nM
For compound 4 the middle estimate is 2.6-fold (0.41 log units) below the measured one; measured number outside the range, above it.
By their numbers in this assay, from the lowest: compounds 3, 2 and 1 (each within the scatter of the next); then compound 4.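

For the compounds shown here, the urea terminus is not indifferent to what it carries: in this assay, the change gives a 2.2-fold higher number from compound 1 to compound 4 (0.33 log units; beyond the scatter), the first step at this place to lie beyond the scatter. The amine-ended chains give the same picture, with a 3.2-fold higher number from compound 3 to compound 4 (0.51 log units; beyond the scatter) and a 2.4-fold higher number from compound 2 to compound 4 (0.39 log units; beyond the scatter), so compound 4 has the highest number of the four, and chain length alone does not account for it, since compound 2 and compound 3 stay within the scatter of compound 1. No measurement shown here offers an explanation for this step.

The compounds shown leave open whether the higher number goes with the carbonyl or with the ring, which a (2-(morpholin-4-yl)ethyl)amino terminus would separate. Going by these compounds, how a carboxylic acid or a longer chain ending in a morpholin-4-yl amide would read at this place also remains open.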